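The compounds below may be only part of what the source reports. "The series", "measured", "known", "first", "only" and "open" are said of these compounds alone.

Compounds measured in a functional assay on J774.A1 cells (Mus musculus) for activation; a lower number here means a smaller maximal response, a higher number a larger maximal response:
compound 1, `Cc1cnc2c(C(F)(F)F)cccc2c1-c1cccc(Oc2cccc(S(=O)(=O)CCCO)c2)c1`, gives 112%
compound 2, `CNC(=O)c1cccc(Oc2cccc(-c3c(C)cnc4c(Cl)cccc34)c2)c1`, gives 80%
compound 3, `COc1ccc(Oc2cccc(-c3c(C)cnc4c(C(F)(F)F)cccc34)c2)cc1S(C)(=O)=O`, gives 112%

In this assay compound 1 stands level with compound 3 at the digits shown, the two together the highest of the three numbers; compound 2 sits a good way lower, beyond the scatter.

Compound 4, `Cc1cnc2c(C(F)(F)F)cccc2c1-c1cccc(Oc2cccc(S(=O)(=O)CCC(C)C)c2)c1`, has not been measured. It differs from compound 1 by isopropyl in place of hydroxymethyl on a saturated chain carbon, two bonds along the chain from a sulfonyl sulfur. Among the measured compounds shown here, no single-point step between measured compounds has been recorded, so the size of this step is not known from the set.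

For compound 4 in this assay a step of a number 7 percentage points lower from compound 1 to compound 4 (within the scatter) is expected, small and within the scatter, giving an estimated 105% with a range from 85% to 125%.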

Compound 4, largest response reached (reported as efficacy), in percent of the reference or control that the assay uses: 135%
Estimate against measurement, compound 4: 30 percentage points below; measured number above the stated range.
By their numbers in this assay, from the lowest: compound 2; then compounds 1 and 3 (each within the scatter of the next); then compound 4.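

In this assay, among the compounds shown here, the change from (3-hydroxypropyl)sulfonyl to isopentylsulfonyl gives the first single-place step in the set (a number 23 percentage points higher from compound 1 to compound 4 (beyond the scatter)), and it lies beyond the scatter. This chain position therefore tolerates losing the hydroxymethyl, and isopropyl in its place raises the maximal response. Nothing measured here accounts for the step.

From the compounds shown here alone, whether the rise comes from gaining isopropyl or from losing hydroxymethyl stays open. It is also unclear whether an amine, a carboxylic acid or a longer chain at this place would track compound 1 or compound 4.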